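Replacing 1-carboxycyclopropyl with 1,3-dicarboxypropyl on an amide-type nitrogen

The source may hold more compounds than are shown below. What is called first, only, known or untested is meant among the compounds shown, and "the series" means these compounds.

Compound 1 `CCn1c(C(=O)NCCC(=O)OC)ccc1C(CC)(CC)c1ccc(OCS(=O)(=O)c2ccccc2)c(C)c1` gives > 50000 nM (a limit)
Compound 2 `CCn1c(C(=O)NC2(C(=O)O)CC2)ccc1C(CC)(CC)c1ccc(OCS(=O)(=O)c2ccccc2)c(C)c1` gives > 50000 nM (a limit)

In a functional assay on BXPC-3 cells (Homo sapiens) for antiproliferative activity, read by MTT assay, with a stated time of 24 h (a lower number here means a stronger inhibitor, a higher number a weaker inhibitor), compound 2 gives > 50000 nM and this is a limit of the assay, not a number. Compound 2 therefore has no exact position on the scale, and the same is true of compound 1. Both compounds share the limit of > 50000 nM in this assay, at which 2 of the 2 values shown sit, and this is all that is known about their standing.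

Compound 3 `CCn1c(C(=O)N[C@@H](CCC(=O)O)C(=O)O)ccc1C(CC)(CC)c1ccc(OCS(=O)(=O)c2ccccc2)c(C)c1` carries 1,3-dicarboxypropyl in place of 1-carboxycyclopropyl on an amide-type nitrogen and so loses the three-membered ring and gains a defined stereocentre.

Within the data shown here, only one measured step bears on this change, and it concerns the group on the same nitrogen. It is a step that the two limits leave unreadable from compound 1 to compound 2 and offers no size to carry over. No change beyond the scatter is therefore expected in this assay in either direction, although this expectation rests on very little. The expected step that the limit leaves unreadable from compound 2 to compound 3 should be read in that light. Compound 3 is expected near 60000 nM within an estimated range of 20000 nM to 180000 nM and will most likely be reported only as a limit.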

Compound 3, half-maximal inhibitory concentration: > 50000 nM
Compound 3 gave a limit, no number; the forecaster's own chance of this, stated with the estimate: 80%; the middle value does not contradict the limit.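

No step can be read among compound 1, compound 2 and compound 3 in this assay, because each gives a limit of the assay rather than a number: the limit of > 50000 nM in this assay, at which 3 of the 3 values shown sit.

On these data alone, what stays open is what the true value of each compound is, and whether exchanging the group on the amide-type nitrogen changes the activity at all.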